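Aryl swap on the pyridine core: indolyl for tolyl

A few compounds are considered here, and "the series" means these few. Any claim that something is new, unique, unknown or untested is made for them only; others in the source may bear on it.

Of the compounds shown here, three have been measured in a functional assay on aorta (strain Wistar) for inhibition, with Thoracic aorta (Rattus norvegicus) as the target (a lower number here means a stronger inhibitor, a higher number a weaker inhibitor), and all three fall within the scatter of one another. Compound 1 `COc1nc(-c2cc3ccccc3o2)cc(-c2ccc(C)cc2)c1C#N` gives 266000 nM, compound 2 `CCOc1nc(-c2cc3ccccc3o2)cc(-c2ccc(C)cc2)c1C#N` gives 290000 nM, and compound 3 `COc1cc(-c2cc(-c3cc4ccccc4o3)nc(OC)c2C#N)cc(OC)c1OC` gives 310000 nM. For the measured compounds named here, the only one-point step measured so far is a 1.1-fold higher number from compound 1 to compound 2 (0.04 log units; within the scatter), an ethoxy in place of a methoxy on the core, and it changes nothing beyond the scatter. Compound 2 stands with the second highest number of the three, with compound 3 and compound 1 each within the scatter of it, so there is no meaningful order among them.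

Compound 4 `CCOc1nc(-c2cc3ccccc3o2)cc(-c2cn(C)c3ccccc23)c1C#N` is the next candidate. The change from compound 2 is 1-methyl-1H-indol-3-yl in place of 4-methylphenyl on an aromatic carbon. Going by the values given here, no measured step in this assay touches this position; the one step on record concerns the alkoxy group only and is within the scatter. The expectation for compound 4 therefore rests on the flat picture given by compounds 1, 2 and 3 alone, and the estimate is placed near compound 2 with a wide range: compound 4 is expected to give 250000 nM in this assay, between 80000 nM and 800000 nM, which means an expected step of a 1.2-fold lower number from compound 2 to compound 4 (0.06 log units; within the scatter).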

Compound 4, half-maximal inhibitory concentration: 327000 nM
The estimate for compound 4 lay 1.3-fold (0.12 log units) below the measured number, and the stated range covers the measured number.
By their numbers in this assay, from the lowest: compounds 1, 2, 3 and 4 (each within the scatter of the next).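

In this assay, the aromatic carbon opposite the ring nitrogen and ortho to a cyano group accepts a much larger exchange than the alkoxy step touched: 1-methyl-1H-indol-3-yl, with 10 heavy atoms, replaces 4-methylphenyl, with 7, and the result is a 1.1-fold higher number from compound 2 to compound 4 (0.05 log units; within the scatter). For the compounds shown here, the exchange adds a five-membered aromatic ring and a hydrogen-bond acceptor to the substituent, yet the number does not move beyond the scatter, so this position now has a direct one-point comparison that the earlier compounds did not supply, and it is flat for this pair. No supporting measurement bears on why the number stays flat here.

Still open, going by these compounds, is whether an amine or a carboxylic acid on the aryl group at this position, or a replacement for the 1-benzofuran-2-yl group, would shift the number beyond the scatter. Neither one-point step on record leaves the scatter, so no group shown can yet be tied to a change in this read-out.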